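The compounds below may be only part of what the source reports. "The series", "measured", "known", "first", "only" and "open" are said of these compounds alone.

Of the compounds shown here, three of one series have been measured in an in vitro assay on HEK385-7 cells for displacement of a labelled ligand from prostaglandin D2 receptor 2 (Homo sapiens); on this read-out lower numbers stand for stronger inhibition and higher numbers for weaker inhibition. Compound 1 `O=C(O)Cc1sc(C(c2ccccc2)c2ccccc2)nc1-c1ccccc1` gives 570 nM. Going by the values given here, compound 3 `O=C(O)Cc1sc(C(c2ccccc2)c2ccccc2)nc1-c1ccc(C(F)(F)F)cc1` gives 1100 nM, and the step of a 1.9-fold higher number from compound 1 to compound 3 (0.29 log units; within the scatter) is the only single-place change among the measured pairs. Among the compounds with values here, compound 2 `O=C(O)Cc1sc(C(c2ccc(F)cc2)c2ccc(F)cc2)nc1-c1ccco1` gives 18 nM, the lowest of the three numbers; compound 1 and compound 3 both lie well beyond the scatter above it, and compound 2 differs from each of them in more than one place, so no single step can be drawn from those pairs.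

Compound 4 `Nc1cc(-c2nc(C(c3ccc(F)cc3)c3ccc(F)cc3)sc2CC(=O)O)cc(F)n1` is not yet measured. It differs from compound 2 in one place: 2-amino-6-fluoropyridin-4-yl in place of furan-2-yl on an aromatic carbon. Within the data shown here, the step from compound 1 to compound 3 concerns a trifluoromethyl group on a different aromatic ring and does not bear on this change, and no measured pair exchanges the group at this position. The expectation therefore rests on compound 2 alone, with a step of a 1.7-fold higher number from compound 2 to compound 4 (0.22 log units; within the scatter) expected to stay within the scatter, in either direction. Compound 4 is estimated at 30 nM in this assay, within a range from 8 nM to 120 nM.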

Compound 4, half-maximal inhibitory concentration: 220 nM
Compound 4: the middle estimate sits 7.3-fold (0.87 log units) below what was measured; measured number above the stated range.
By their numbers in this assay, from the lowest: compound 2; then compound 4; then compounds 1 and 3 (each within the scatter of the next).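

Swapping the group at this position is not neutral: in this assay, 2-amino-6-fluoropyridin-4-yl in place of furan-2-yl gives a 12-fold higher number from compound 2 to compound 4 (1.09 log units; beyond the scatter) on an otherwise unchanged structure, a step beyond the usual scatter. Going by these compounds alone, this is the first single-place change at this ring carbon, and it shows that the number here depends strongly on which aromatic group is attached. No measurement shown here explains why.

The entering group differs from furan-2-yl in several ways at once, with a six-membered ring, an amino group and a fluorine, so it remains unclear which of these accounts for the step. A plain pyridin-4-yl or a thiophen-2-yl group at this same place would help to separate the ring change from the effect of the added amino group and fluorine.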